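This account rests on a few compounds, and the source may have more. Where it says the series, first, only, none or still open, it means among the compounds named here.

Among the measured compounds shown here, in an in vivo ADME assay on the whole organism (strain CD-1) for pharmacokinetics, with Mus musculus as the target, at a dose of 10 mg/kg by the oral route (on this read-out higher numbers stand for higher oral bioavailability and lower numbers for lower oral bioavailability), compound 1 `COc1cc(N2CCC(CC(=O)N3CCOCC3)CC2)ccc1Nc1nc(NC2CCCCC2)c2nc[nH]c2n1` gives 23.1% and compound 2 `COc1cc(N2CCC(CC(=O)N3CCN(C)CC3)CC2)ccc1Nc1nc(NC2CCCCC2)c2nc[nH]c2n1` gives 6.9%, the lower of the two numbers so far. Compound 3 `COc1cc(N2CCC(CC(=O)N3CCCC3)CC2)ccc1Nc1nc(NC2CCCCC2)c2nc[nH]c2n1` has pyrrolidin-1-yl in place of the 4-methylpiperazin-1-yl of compound 2 on a carbonyl carbon: pyrrolidin-1-yl in place of 4-methylpiperazin-1-yl on a carbonyl carbon. For the measured compounds named here, the only measured step at this place, a number 16.2 percentage points lower from compound 1 to compound 2 (beyond the scatter), is modest but beyond the scatter. Going by the values given here, no pyrrolidin-1-yl compound has been measured yet. On that one step, a rise of similar size is expected, estimated as a number 13.1 percentage points higher from compound 2 to compound 3 (beyond the scatter). The expected value for compound 3 is 20%, with an estimated range of 8% to 34%.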

Compound 3, oral bioavailability: 36%
For compound 3 the middle estimate is 16 percentage points below the measured one; the whole stated range lies below it.
By their numbers in this assay, from the lowest: compound 2; then compound 1; then compound 3.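

In this assay, pyrrolidin-1-yl on the carbonyl carbon gives a number 29.1 percentage points higher from compound 2 to compound 3 (beyond the scatter) and also a number 12.9 percentage points higher from compound 1 to compound 3 (beyond the scatter). The change at this position therefore reaches beyond the morpholin-4-yl level, and the three groups now stand apart in oral bioavailability. No evidence at hand accounts for this order.

The compounds shown cannot separate ring size from the second ring hetero atom, since the five-membered ring differs from both others in each. Piperidin-1-yl, a six-membered ring with only the amide nitrogen, would separate the two.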